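The source may report more compounds than this note shows. Statements on the series, on what has been measured and on what is new or still open speak of the compounds shown alone.

Measured so far in a functional assay on MCF7 cells (Homo sapiens) for cytotoxicity, read by sulforhodamine B assay, with a stated time of 48 h, tested at 1 uM; on this read-out higher numbers stand for a weaker effect at the one concentration tested and lower numbers for a stronger effect:
compound 1, `COc1cc(-c2cc(/C=C/C(=O)c3ccc(N)cc3)[nH]n2)cc(OC)c1OC`: 66%
compound 2, `COc1ccc(-c2cc(/C=C/C(=O)c3ccc(N)cc3)[nH]n2)cc1OC`: 81%
compound 3, `COc1cc(C(=O)/C=C/c2cc(-c3cc(OC)c(OC)c(OC)c3)n[nH]2)cc(OC)c1OC`: 40%

Compound 2 differs from compound 1 by hydrogen in place of methoxy on an aromatic carbon and this change gave a number 15 percentage points higher from compound 1 to compound 2 (beyond the scatter). How the core of compound 3 differs from that of compound 1 is not broken down here; compound 3 stands lowest of the three values, beyond the scatter from both compound 1 and compound 2.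

Compound 4, `COc1ccc(-c2cc(/C=C/C(=O)c3cc(OC)c(OC)c(OC)c3)[nH]n2)cc1OC`, is not yet measured. It differs from compound 3 by hydrogen in place of methoxy on an aromatic carbon, the same change as from compound 1 to compound 2, at a place described in the same words. Because the earlier step was a number 15 percentage points higher from compound 1 to compound 2 (beyond the scatter), a step of the same size and direction is expected here, namely a number 15 percentage points higher from compound 3 to compound 4 (beyond the scatter), though this rests on a single earlier pair. Compound 4 is therefore estimated at 55%, with the range 40% to 75%.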

Compound 4, a percentage reported as activity, at one concentration (the size of the read-out at that concentration, not a potency): 53%
The estimate for compound 4 lay 2 percentage points above the measured number, within the range that was stated.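

In this assay, hydrogen in place of methoxy on an aromatic carbon gave a number 13 percentage points higher from compound 3 to compound 4 (beyond the scatter), and the two steps agree across the two cores: the same change on two cores in this assay, a number 15 percentage points higher (beyond the scatter) from compound 1 to compound 2 and a number 13 percentage points higher (beyond the scatter) from compound 3 to compound 4, 2 percentage points apart, within the scatter of two such steps In this series, the change therefore carried from the core of compound 1 to the core of compound 3 with its direction and approximate size kept, so adding the step to the value of the parent compound held for this pair. This rests on two pairs at a single concentration, so it shows neither a change in potency nor a rule for other cores or other ring places.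

The compounds shown leave open whether a hydroxy group, a chlorine or an ethoxy group in place of that methoxy would fall in line with these steps. They also leave open how the step would behave on a core carrying a carboxylic acid.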